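This account rests on a few compounds, and the source may have more. Where it says the series, first, only, none or still open, it means among the compounds named here.

Measured compounds in a functional assay on Caco-2 cells (Homo sapiens) for cytotoxicity, with a stated time of 24 h; a higher number here means a weaker inhibitor, a lower number a stronger inhibitor: compound 1 `O=C(Nc1ccccc1)c1c(-c2ccc(Cl)cc2)c(-c2ccccc2)nn1-c1ccccc1` gives 1.74 ug/mL; compound 2 `Cc1ccc(NC(=O)c2c(-c3ccc(Cl)cc3)c(-c3ccccc3)nn2-c2ccccc2)cc1` gives 1.54 ug/mL; compound 3 `O=C(c1c(-c2ccccc2)c(-c2ccccc2)nn1-c1ccccc1)n1c(=S)[nH]c2ccccc21` gives 1.48 ug/mL.

Compound 3 holds the smallest of the three numbers, but its distance to compound 2 and to compound 1 lies within the scatter in each case, so the three stand level.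

Compound 4 `O=C(c1c(-c2ccc(Cl)cc2)c(-c2ccccc2)nn1-c1ccccc1)n1c(=S)[nH]c2ccccc21` is compound 3 with chloro in place of hydrogen on an aromatic carbon. Going by the values given here, the only single-point step on record is a 1.1-fold lower number from compound 1 to compound 2 (0.05 log units; within the scatter), a different substituent at a comparable place, and it stayed within the scatter. Compounds 1 and 2, which already carry the 4-chlorophenyl, show numbers no different from compound 3. No step beyond the scatter is therefore expected in this assay from the chloro.

Compound 4 is estimated at 1.4 ug/mL, range 0.7 ug/mL to 2.8 ug/mL, an expected step of a 1.1-fold lower number from compound 3 to compound 4 (0.02 log units; within the scatter).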

Compound 4, half-maximal inhibitory concentration: 3.29 ug/mL
The estimate for compound 4 lay 2.4-fold (0.37 log units) below the measured number, and the stated range ends below it.
By their numbers in this assay, from the lowest: compounds 3, 2, 1 and 4 (each within the scatter of the next, the first and the last beyond it).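

In this assay, phenyl to 4-chlorophenyl is not neutral on this scaffold: the change para to a large group gives a 2.2-fold higher number from compound 3 to compound 4 (0.35 log units; beyond the scatter), a modest step. With the 4-chlorophenyl held, the change of group on the carbonyl carbon gives a 2.1-fold higher number from compound 2 to compound 4 (0.33 log units; beyond the scatter), also modest, and a 1.9-fold higher number from compound 1 to compound 4 (0.28 log units; within the scatter). Nothing available accounts for the chloro step.

Open, from the compounds shown here alone, is whether fluoro, methoxy or an amine at this place would give a similar step. Also open, going by these compounds, is whether the chloro step holds with the carbonyl group of compound 1.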